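This account rests on a few compounds, and the source may have more. Where it says the series, first, only, none or still open, it means among the compounds named here.

Measured so far:
compound 1, `COc1cccc(NCc2ccc(/C=C/C(=O)Nc3ccccc3N)cc2)c1`: 10000 nM
compound 2, `COc1ccc(NCc2ccc(/C=C/C(=O)Nc3ccccc3N)cc2)cc1OC`: 5000 nM
compound 3, `COc1ccc(CNc2ccc(C(=O)Nc3ccccc3N)cc2)cc1`: 1000 nM

These values come from a functional assay on HCT-116 cells (Homo sapiens) for antiproliferative activity, read by MTT assay (a lower number here means a stronger inhibitor, a higher number a weaker inhibitor), which tells how strongly each compound holds back the growth of a colon cancer cell line. Compound 4, `COc1ccc(CNc2ccc(C(=O)Nc3ccccc3N)cc2)cc1OC`, has not yet been measured in this assay. It differs from compound 3 by methoxy in place of hydrogen on an aromatic carbon. The same kind of change separates compound 1 from compound 2: methoxy in place of hydrogen on an aromatic carbon. The two places are not identical: in the pair of compounds 1 and 2 the entering group sits para to a large group, in the pair of compounds 3 and 4 it sits meta to a large group. How the core of compound 1 differs from the core of compound 3 is not broken down here. The earlier step, a 2.0-fold lower number from compound 1 to compound 2 (0.30 log units; within the scatter), lies within the scatter, and a step of similar size is expected here. For compound 4 the expected step is a 1.3-fold lower number from compound 3 to compound 4 (0.10 log units; within the scatter). The estimate for compound 4 in this assay is 800 nM, with a range from 300 nM to 2500 nM.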

Compound 4, half-maximal inhibitory concentration: 600 nM
Beside the measured number, compound 4's estimate is 1.3-fold (0.12 log units) above it, within the range that was stated.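

In this assay, the added methoxy group gives a 1.7-fold lower number from compound 3 to compound 4 (0.22 log units; within the scatter), and this step agrees with the earlier one on the other core: the same change on two cores in this assay, a 2.0-fold lower number (0.30 log units; within the scatter) from compound 1 to compound 2 and a 1.7-fold lower number (0.22 log units; within the scatter) from compound 3 to compound 4, 1.2-fold (0.08 log units) apart, within the scatter of two such steps. On these two cores the change therefore behaves alike, and on neither does it separate the pair by more than repeated measurements would. This does not show that the methoxy group helps on either core, and two pairs, with the group entering at different places, cannot show that the result would hold on further cores in this series.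

The compounds shown leave open what other groups would do at this place, such as a hydroxyl group, a carboxylic acid or a longer chain like ethoxy.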